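Trifluoromethoxy in Place of Fluoro: Expected Potency Shift

The source may report more compounds than this note shows. Statements on the series, on what has been measured and on what is new or still open speak of the compounds shown alone.

Going by the values given here, compound 1 `O=C(O)CCc1ccc2[nH]c(-c3ccccc3F)cc2c1` is the only compound with a numerical value here: in a functional assay on CHO cells for agonist activity at Free fatty acid receptor 1 (Homo sapiens), read by a luciferase reporter, with a stated time of 24 h (a higher number here means that more compound is needed for the effect, a lower number that less compound is needed), compound 1 gives 1210 nM. Compound 2 `COc1cccc(-c2cc3cc(CCC(=O)O)ccc3[nH]2)c1`, by comparison, gives only a limit in this assay, namely > 25 nM, and no number. Compound 3 `O=C(O)CCc1ccc2[nH]c(-c3ccccc3OC(F)(F)F)cc2c1` differs from compound 1 by trifluoromethoxy in place of fluoro on an aromatic carbon. Among the compounds with values here, no measured pair shows the effect of such a change, so the step from compound 1 to compound 3 in this assay is expected to be small, about a 1.3-fold lower number from compound 1 to compound 3 (0.13 log units; within the scatter), and within the usual scatter. Compound 3 is therefore estimated at 900 nM, with a range from 250 nM to 3500 nM.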

Compound 3, half-maximal effective concentration: 1020 nM
For compound 3 the middle estimate is 1.1-fold (0.05 log units) below the measured one; the measured number falls inside the stated range.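

In this assay, trifluoromethoxy in place of fluoro gives a 1.2-fold lower number from compound 1 to compound 3 (0.07 log units; within the scatter). The position, ortho to a large group, thus takes a group of 5 heavy atoms in place of one of 1 with no change beyond the scatter. Nothing shown explains why the two groups read alike. For compound 2 the reading of > 25 nM is a limit and not a number. As far as these compounds go, whether an amine or a carboxylic acid at this position would also leave the reading within the scatter stays open.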